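Ester to acid on the shared core, tested on breast cancer cells

The compounds below may be only part of what the source reports. "The series", "measured", "known", "first", "only" and "open" are said of these compounds alone.

The study concerns three measured compounds and one that awaits measurement, all built on the shared core seen in compound 1 `COc1ccc(-c2oc3c(CC=C(C)C)c(OCC(=O)O)cc(O)c3c(=O)c2OCC(=O)O)cc1`. In a functional assay on MCF7 cells (Homo sapiens) for cytotoxicity, read by MTT assay (on this read-out higher numbers stand for weaker inhibition and lower numbers for stronger inhibition), compound 1 gives only a limit, > 100000 nM. Compound 3 `COc1ccc(-c2oc3c(CC=C(C)C)c(OCCCOC(=O)CCC(=O)O)cc(O)c3c(=O)c2OCCCOC(=O)CCC(=O)O)cc1` likewise gives only a limit in this assay, > 100000 nM. Among the compounds with values here, compound 2 `CCOC(=O)COc1cc(O)c2c(=O)c(O)c(-c3ccc(OC)cc3)oc2c1CC=C(C)C` is the one compound with a number: in this assay compound 2 gives 27900 nM, the only measurable value among the three.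

Compound 4 `COc1ccc(-c2oc3c(CC=C(C)C)c(OC(C)C(=O)O)cc(O)c3c(=O)c2O)cc1` is the unmeasured member. It differs from compound 2 in one place: 1-carboxyethyl in place of (ethoxycarbonyl)methyl on an oxygen on an aromatic ring. Within the data shown here, no step between measured compounds is available for this kind of change, so the expectation rests on where the set as a whole sits. Two of the three measured compounds reach (the limit of > 100000 nM in this assay, at which 2 of the 3 values shown sit), and this weighs on the estimate. Compound 4 is therefore expected to come out weaker than compound 2, with a step from compound 2 to compound 4 estimated at a 2.9-fold higher number from compound 2 to compound 4 (0.46 log units; beyond the scatter), and a fair chance that only a limit is reported. The estimate for compound 4 is 80000 nM, within 30000 nM to 200000 nM.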

Compound 4, half-maximal inhibitory concentration: > 100000 nM
Compound 4: no number, only a limit; the forecaster's own chance of this, stated with the estimate: 55%; at least 1.2-fold (0.09 log units) between middle value and limit.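

Within the data shown here, compound 4 gives the first readable step at this oxygen on an aromatic ring: putting 1-carboxyethyl in place of (ethoxycarbonyl)methyl yields an at least 3.5-fold higher number from compound 2 to compound 4 (0.55 log units; beyond the scatter). The step gives only a minimum size, since compound 4 is reported in this assay only as a limit, > 100000 nM. Compounds 1 and 3 differ from compound 2 in more than one place, so they could not tie the loss of a measurable value to this single change, and with compound 4 added, compound 2 remains the only compound with a number, while the others share one limit: the limit of > 100000 nM in this assay, at which 3 of the 4 values shown sit.

The change replaces the ester with a carboxylic acid and also alters the chain, and the compounds shown do not separate these two parts; a compound with 1-(ethoxycarbonyl)ethyl on this oxygen would bear directly on that question. As far as these compounds go, it also remains open how far past its limit compound 4 lies, and whether an amide, an amine or a longer ester chain at this oxygen would give a measurable value in this assay.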